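The source may hold more compounds than are shown below. What is called first, only, known or untested is meant among the compounds shown, and "the series" means these compounds.

Compound 2 `CCc1ccccc1-n1cc(COc2cccc(NC(=O)Nc3ccc(Cl)c(C(F)(F)F)c3)c2)nn1` and compound 1 `N#Cc1cccc(-n2cc(COc3cccc(NC(=O)Nc4ccc(Cl)c(C(F)(F)F)c4)c3)nn2)c1` share one core and differ only in the group on the aromatic nitrogen. In a functional assay on HepG2 cells (Homo sapiens) for inhibition, read by MTT assay, with a stated time of 72 h (on this read-out higher numbers stand for weaker inhibition and lower numbers for stronger inhibition), compound 1 gives 2760 nM and compound 2 gives 3530 nM; the two sit together, with a 1.3-fold higher number from compound 1 to compound 2 (0.11 log units; within the scatter). Compound 3 `O=C(Nc1cccc(OCc2cn(-c3ccccc3I)nn2)c1)Nc1ccc(Cl)c(C(F)(F)F)c1` carries iodo in place of ethyl on an aromatic carbon, the 2-ethylphenyl of compound 2 becoming 2-iodophenyl. Within the data shown here, the only step in hand, 3-cyanophenyl to 2-ethylphenyl, was flat, and nothing addresses iodo directly. For compound 3 in this assay a number near compound 2 is expected, the step of a 1.0-fold lower number from compound 2 to compound 3 (0.00 log units; within the scatter) staying within scatter, so compound 3 is estimated at 3500 nM within 1500 nM to 8000 nM.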

Compound 3, half-maximal inhibitory concentration: 2870 nM
Beside the measured number, compound 3's estimate is 1.2-fold (0.09 log units) above it, within the range that was stated.
By their numbers in this assay, from the lowest: compounds 1, 3 and 2 (each within the scatter of the next).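

In this assay the change from 2-ethylphenyl to 2-iodophenyl gives a 1.2-fold lower number from compound 2 to compound 3 (0.09 log units; within the scatter) and so shows that iodo and ethyl cannot be told apart at this position. The change from 3-cyanophenyl to 2-iodophenyl gives a 1.0-fold higher number from compound 1 to compound 3 (0.02 log units; within the scatter) and places all three groups on the aromatic nitrogen within the scatter of one another. No measurement at hand offers a reason for this flat result. From the compounds shown here alone, whether an amine, a carboxylic acid or a longer chain on this aromatic ring would shift the number remains open.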